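Fluorine on the benzyl group of a weak adenosine ligand

The source may report more compounds than this note shows. Statements on the series, on what has been measured and on what is new or still open speak of the compounds shown alone.

The measured compounds and their values:
compound 1, `CCCNc1nc(-c2ccccc2)nc2c1nnn2Cc1ccccc1`, 37000000 nM;
compound 2, `c1ccc(Cn2nnc3c(NC4CC4)nc(-c4ccccc4)nc32)cc1`, 11000000 nM;
compound 3, `c1ccc(Cn2nnc3c(NC4CCCC4)nc(-c4ccccc4)nc32)cc1`, 11000000 nM.

All three were measured in an assay on isolated protein for binding affinity to adenosine receptor A1 (Bos taurus); a lower number here means a stronger inhibitor, a higher number a weaker inhibitor. Compound 1 gives the highest of the three numbers in this assay. The two steps away from it, a 3.4-fold lower number from compound 1 to compound 2 (0.53 log units; beyond the scatter) and a 3.4-fold lower number from compound 1 to compound 3 (0.53 log units; beyond the scatter), are both modest, and the step of no change at the digits printed from compound 2 to compound 3 (within the scatter) shows that cyclopropyl and cyclopentyl on the ring nitrogen are not distinguished at the digits reported.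

Compound 4, `CCCNc1nc(-c2ccccc2)nc2c1nnn2Cc1ccccc1F`, differs from compound 1 in one place: fluoro in place of hydrogen on an aromatic carbon.

For the measured compounds named here, none of the measured steps touches this part of the molecule; each of them changes the group on the ring nitrogen and leaves the benzyl group as it is. Going by the values given here, there is therefore no measured step that bears directly on the change from compound 1 to compound 4, and the expectation rests only on the fact that the rest of the structure is unchanged and that compound 1 itself is a very weak binder. For compound 4 the expected step is a 1.2-fold lower number from compound 1 to compound 4 (0.09 log units; within the scatter), that is, nothing beyond the scatter. The estimated value for compound 4 in this assay is 30000000 nM, with a range from 8000000 nM to 110000000 nM.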

Compound 4, inhibition constant: 3200000 nM
The estimate for compound 4 lay 9.4-fold (0.97 log units) above the measured number, outside the stated range (below it).
By their numbers in this assay, from the lowest: compound 4; then compounds 2 and 3 (each within the scatter of the next); then compound 1.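

In this assay, for the compounds shown here, the benzyl group proves to be a part of the molecule that responds to change: going to 2-fluorobenzyl gives a 12-fold lower number from compound 1 to compound 4 (1.06 log units; beyond the scatter) and is the first measured step here, as all the earlier steps changed only the group on the ring nitrogen. This one fluoro, a single heavy atom with no ring and no net charge, gives a step printed as large, whereas the replacements of propyl on the nitrogen gave a 3.4-fold lower number from compound 1 to compound 2 (0.53 log units; beyond the scatter) and a 3.4-fold lower number from compound 1 to compound 3 (0.53 log units; beyond the scatter) and are printed as modest. Nothing measured here explains why this hydrogen-to-fluoro change has such an effect.

The compounds shown leave open whether chloro, methyl or methoxy on this same aromatic carbon would also lower the number, and whether fluoro would do so on another carbon of that six-membered ring. They also leave open whether the 2-fluorobenzyl group would give a similar step with the cyclopropyl of compound 2 or the cyclopentyl of compound 3 on the ring nitrogen.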